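This account rests on a few compounds, and the source may have more. Where it says the series, first, only, none or still open, it means among the compounds named here.

Compound 1 `CCCCn1ccc2cc(/C(C)=C/C(=O)Nc3ccccc3OCCCC(=O)O)ccc21` gives 43 nM in an assay on Prostate gland for inhibition of steroid 5-alpha-reductase (Rattus norvegicus); a higher number here means a weaker inhibitor, a lower number a stronger inhibitor.
Compound 2 `CCCCCC(CCCCC)n1ccc2cc(/C(C)=C/C(=O)Nc3ccccc3OCCCC(=O)O)ccc21` gives 25 nM in this assay.

Among the measured compounds shown here, compound 2 carries the lowest of the two numbers in this assay, though the only step measured, a 1.7-fold lower number from compound 1 to compound 2 (0.24 log units; within the scatter), stays within the scatter. Compound 3 `C/C(=C\C(=O)Nc1ccccc1OCCCC(=O)O)c1ccc2c(ccn2Cc2ccc(C(C)(C)C)cc2)c1` differs from compound 2 by 4-(tert-butyl)benzyl in place of 1-pentylhexyl on an aromatic nitrogen. For the measured compounds named here, the single measured step at that nitrogen exchanged one chain for another chain and moved little; no measured step introduces an aromatic ring there, so no direction is supported by the data. Compound 3 is therefore expected to stay near compound 2 in this assay, estimated at 20 nM with a range of 7 nM to 60 nM. This estimate corresponds to a step of a 1.3-fold lower number from compound 2 to compound 3 (0.10 log units; within the scatter).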

Compound 3, half-maximal inhibitory concentration: 170 nM
Compound 3: the middle estimate sits 8.5-fold (0.93 log units) below what was measured; the whole stated range lies below it.
By their numbers in this assay, from the lowest: compounds 2 and 1 (each within the scatter of the next); then compound 3.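

In this assay the aromatic nitrogen no longer looks tolerant: a ring-bearing group gives a 6.8-fold higher number from compound 2 to compound 3 (0.83 log units; beyond the scatter) and a 4.0-fold higher number from compound 1 to compound 3 (0.60 log units; beyond the scatter), both beyond the scatter, while the exchange of one chain for another stayed within it. 1-pentylhexyl and 4-(tert-butyl)benzyl have equal heavy-atom counts, so that count alone does not track the number at this position. No available evidence accounts for the rise.

Open, on these data alone, is whether the rise goes with the aromatic ring or with the tert-butyl group. A plain benzyl group, or a benzyl group carrying an amine, would separate these readings.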